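Acetyl in Place of Methoxy on a Shared Core

The source may hold more compounds than are shown below. What is called first, only, known or untested is meant among the compounds shown, and "the series" means these compounds.

compound 1 `COc1ccc(-c2cn3ccnc3c(-c3ccc4ncn(C5CCCCC5)c4c3)n2)cc1`: -8.6%
compound 2 `O=Cc1ccc(-c2cn3ccnc3c(-c3ccc4ncn(C5CCCCC5)c4c3)n2)cc1`: 98%

In a functional assay on T47D cells (Homo sapiens) for inhibition, read by sulforhodamine B assay, with a stated time of 48 h, tested at 10 uM (on this read-out lower numbers stand for less inhibition and higher numbers for more inhibition at the one concentration tested (going by the name of the read-out)), compound 1 gives -8.6%, the lowest of the two numbers, while compound 2 gives 98%. Among the compounds with values here, the only measured step, a number 106.6 percentage points higher from compound 1 to compound 2 (beyond the scatter), is large and upward. Compound 3 `CC(=O)c1ccc(-c2cn3ccnc3c(-c3ccc4ncn(C5CCCCC5)c4c3)n2)cc1` differs from compound 1 by acetyl in place of methoxy on an aromatic carbon. Because the step of a number 106.6 percentage points higher from compound 1 to compound 2 (beyond the scatter) was large, and acetyl like formyl carries a carbonyl, a large upward step is expected, estimated as a number 88.6 percentage points higher from compound 1 to compound 3 (beyond the scatter). Compound 3 is expected to give about 80%, with a range from 40% to 100%.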

Compound 3, a percentage reported as inhibition, at one concentration (the size of the read-out at that concentration, not a potency): 54.4%
For compound 3 the middle estimate is 25.6 percentage points above the measured one, and the stated range covers the measured number.
By their numbers in this assay, from the lowest: compound 1; then compound 3; then compound 2.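

In this assay, acetyl also gives a number 63 percentage points higher from compound 1 to compound 3 (beyond the scatter), so at this place, para to a large group, the upward step is not limited to formyl. Even so, the carbonyl alone does not fix the number: methyl in place of hydrogen on the carbonyl carbon gives a number 43.6 percentage points lower from compound 2 to compound 3 (beyond the scatter), so what sits on that carbon also counts. No measurement available here accounts for either step. As far as these compounds go, whether an amide or a carboxylic acid would behave like formyl or acetyl remains open. So does the effect of a longer chain on the carbonyl carbon, such as propanoyl.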